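A few compounds are considered here, and "the series" means these few. Any claim that something is new, unique, unknown or untested is made for them only; others in the source may bear on it.

Compound 1 `ClCc1cccc(Cn2cnc3c(Cl)nc(Cl)nc32)c1` carries two chloro groups on its core, and in a functional assay on SK-OV-3 cells (Homo sapiens) for cytotoxicity, read by sulforhodamine B assay, with a stated time of 48 h (a higher number here means a weaker inhibitor of growth, a lower number a stronger inhibitor of growth), compound 1 gives "not determined" (no result reported), so there is no number on which it can be placed. Its companions offer the only footing. Compound 2 `Nc1nc(Cl)c2ncn(Cc3ccccc3CCl)c2n1` bears an amino group where compound 1 bears its second chloro. In this assay compound 2 gives 52500 nM. Compound 3 `ClCc1ccccc1Cn1cnc2c(Cl)ncnc21`, which bears hydrogen at that place, gives 15900 nM. The step of a 3.3-fold lower number from compound 2 to compound 3 (0.52 log units; beyond the scatter) shows that removing a group at this position of the core moved the number only modestly.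

Compound 4 `ClCc1cccc(Cn2cnc3c(Cl)ncnc32)c1` differs from compound 1 by hydrogen in place of chloro on an aromatic carbon. The measured step concerns amino rather than chloro, and it starts from a compound with a known value, so it bears on the change only loosely. Compound 3 shares the core of compound 4 and differs from it only in the arrangement of the benzyl group, and its value is the nearest guide. Compound 4 is therefore expected to give about 16000 nM in this assay, with a range from 5000 nM to 50000 nM.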

Compound 4, concentration for total growth inhibition: 10500 nM
Compound 4: the middle estimate sits 1.5-fold (0.18 log units) above what was measured, within the range that was stated.
By their numbers in this assay, from the lowest: compounds 4 and 3 (each within the scatter of the next); then compound 2.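

Going by these compounds alone, compound 1 has no number in this assay, so compound 4 at 10500 nM gives no step that can be read between the two. On these data alone, what the chloro group on compound 1 does to growth inhibition therefore stays open. The data shown offer no explanation for these values.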